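Removing the ring chlorine: expected cytotoxicity of compound 3

A few compounds are considered here, and "the series" means these few. Any claim that something is new, unique, unknown or untested is made for them only; others in the source may bear on it.

Measured compounds:
- Compound 1, `CC(CSc1nnc(-c2ccncc2)s1)C(=O)Nc1ccc(Cl)cc1Cl`, in an ADME assay on HepG2 cells (Homo sapiens) for cytotoxicity, with a stated time of 3 days (on this read-out lower numbers stand for higher toxicity in this test and higher numbers for lower toxicity in this test), gives > 50000 nM, which is a limit of the assay.
- Compound 2, `CC(CSc1nnc(-c2ccncc2)s1)C(=O)NCc1ccc(Cl)cc1`, in this assay gives "not determined" (no result reported).

Within the data shown here, compound 2 thus has no number on record; the only value shown sits at the limit of > 50000 nM in this assay, at which 1 of the 2 values shown sits. The step from compound 2 to compound 3, `CC(CSc1nnc(-c2ccncc2)s1)C(=O)NCc1ccccc1`, is hydrogen in place of chloro on an aromatic carbon, in words hydrogen in place of chloro on an aromatic carbon. Among the measured compounds shown here, no measured step exists to size this change, so nothing beyond the scatter is expected in this assay in either direction. Compound 3 is therefore estimated at 50000 nM, within 20000 nM to 100000 nM, most probably again reported only as a limit.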

Compound 3, half-maximal cytotoxic concentration: > 50000 nM
Compound 3: only a limit was reported; the forecaster's own chance of this, stated with the estimate: 80%; the middle value lies on the limit itself.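

In this assay compound 3 gives > 50000 nM, a limit of the assay. Among these compounds, compound 1 also rests on a limit, so no step from compound 1 to compound 3 can be read. The compounds shown leave open what the change from 4-chlorobenzyl to benzyl does in this assay.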